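Sulfonyl aryl variation in the indole-azaindole series

This account rests on a few compounds, and the source may have more. Where it says the series, first, only, none or still open, it means among the compounds named here.

Three compounds share one core and differ only in the group on the methylated nitrogen. Compound 1 `CC(=O)N(C)c1ccc2[nH]c(-c3n[nH]c4ccccc34)cc2n1` carries an acetyl group, and in a functional assay on KB cells (Homo sapiens) for antiproliferative activity, read by MTT assay, with a stated time of 72 h (on this read-out higher numbers stand for weaker inhibition and lower numbers for stronger inhibition), compound 1 gives 10300 nM. Compound 2 `CN(C(=O)C(C)(C)C)c1ccc2[nH]c(-c3n[nH]c4ccccc34)cc2n1` carries a tert-butyl carbonyl, and in this assay compound 2 gives 8390 nM. Compound 3 `Cc1ccc(S(=O)(=O)N(C)c2ccc3[nH]c(-c4n[nH]c5ccccc45)cc3n2)cc1` carries a (4-methylphenyl)sulfonyl, and in this assay compound 3 gives 9500 nM. The three steps are a 1.2-fold lower number from compound 1 to compound 2 (0.09 log units; within the scatter), a 1.1-fold lower number from compound 1 to compound 3 (0.04 log units; within the scatter) and a 1.1-fold higher number from compound 2 to compound 3 (0.05 log units; within the scatter), each within the scatter, so the three values sit together and compound 3 stands second highest of the three without being separable from either neighbour.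

Compound 4 `CN(c1ccc2[nH]c(-c3n[nH]c4ccccc34)cc2n1)S(=O)(=O)c1ccc(OC(F)(F)F)cc1` keeps the sulfonyl on the nitrogen and changes the aryl group: trifluoromethoxy in place of methyl on an aromatic carbon. Among the measured compounds shown here, no measured step alters this aryl group, so the bearing of the data is indirect: every change so far, acyl to sulfonyl included, has left this assay flat, and the series gives no sign of sensitivity at this end of the molecule. The expectation for compound 4 is therefore a step of about a 1.1-fold lower number from compound 3 to compound 4 (0.02 log units; within the scatter), that is, none beyond the scatter. Compound 4 is estimated at 9000 nM in this assay, within a range of 4000 nM to 20000 nM.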

Compound 4, half-maximal inhibitory concentration: 1330 nM
Compound 4: middle estimate off by 6.8-fold (0.83 log units), on the high side; the measured number lies below the stated range.
By their numbers in this assay, from the lowest: compound 4; then compounds 2, 3 and 1 (each within the scatter of the next).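

Among the compounds shown here, the aryl group on the sulfonyl is the first part of this series where this assay moves beyond the scatter: 4-(trifluoromethoxy)phenyl in place of 4-methylphenyl gives a 7.1-fold lower number from compound 3 to compound 4 (0.85 log units; beyond the scatter) on a single substituent change, whereas acetyl to (4-methylphenyl)sulfonyl on the nitrogen gave only a 1.1-fold lower number from compound 1 to compound 3 (0.04 log units; within the scatter) within the scatter. The flat values of compound 1, compound 2 and compound 3 therefore said nothing about this aromatic carbon, para to a large group, and the series is sensitive to what sits there. No measurement given here accounts for the size of this step.

With a single pair at this position, the step cannot be divided among the oxygen, the fluorine atoms and the larger group as a whole; methoxy, trifluoromethyl or chlorine on the same aromatic carbon would separate those parts. On these data alone, whether the step depends on the sulfonyl link also stays open, and a 4-(trifluoromethoxy)benzoyl group on the same nitrogen would address that.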